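The compounds below may be only part of what the source reports. "The series", "measured", "known", "first", "only" and "open" are said of these compounds alone.

Compound 1 `Cn1nnnc1SCC(=O)N/N=c1/scc(-c2ccc(C#N)cc2)n1-c1ccccc1` and compound 2 `COc1ccc(-c2cs/c(=N/NC(=O)CSc3nnnn3C)n2-c2ccccc2)cc1` share one core and differ only in a single group on a six-membered aromatic ring of carbon only. In an ADME assay on NIH3T3 cells (Mus musculus) for cytotoxicity, read by MTT assay, with a stated time of 24 h (a lower number here means a stronger inhibitor, a higher number a weaker inhibitor), compound 1 gives 213 ug/mL, and in this assay compound 2 gives 45 ug/mL. The step between them, a 4.7-fold lower number from compound 1 to compound 2 (0.68 log units; beyond the scatter), came from methoxy in place of cyano on an aromatic carbon. Among the compounds with values here, compound 2 therefore holds the lowest of the two numbers so far, with compound 1 the only neighbour.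

Compound 3 `Cc1ccc(-c2cs/c(=N/NC(=O)CSc3nnnn3C)n2-c2ccccc2)cc1` differs from compound 2 by methyl in place of methoxy on an aromatic carbon. Within the data shown here, no measured step trades methoxy for methyl, so the only guide is the modest step from compound 1 to compound 2, which shows that a change at this position can move this assay beyond the scatter. A step of similar or smaller size in either direction is plausible. Compound 3 is expected to give 60 ug/mL, within 25 ug/mL to 150 ug/mL, an expected step of a 1.3-fold higher number from compound 2 to compound 3 (0.12 log units; within the scatter).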

Compound 3, half-maximal inhibitory concentration: 243 ug/mL
Compound 3: middle estimate off by 4.1-fold (0.61 log units), on the low side; measured number above the stated range.
By their numbers in this assay, from the lowest: compound 2; then compounds 1 and 3 (each within the scatter of the next).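

In this assay, replacing methoxy with methyl gives a 5.4-fold higher number from compound 2 to compound 3 (0.73 log units; beyond the scatter) and so does not keep the low number of compound 2, while replacing cyano with methyl gives a 1.1-fold higher number from compound 1 to compound 3 (0.06 log units; within the scatter) and leaves the two values within the scatter of each other. Among the three groups shown at this position, para to a large group, methoxy alone stands apart, so the earlier drop cannot be read as a result of simply removing cyano. No measurement at hand explains why methoxy differs from the other two groups.

As far as these compounds go, it remains open whether a hydroxyl, ethoxy or amine group here would give a number near that of compound 2 or near those of compound 1 and compound 3. From the compounds shown here alone, it is also open whether methoxy would have the same effect on a different core.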